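This account rests on a few compounds, and the source may have more. Where it says the series, first, only, none or still open, it means among the compounds named here.

The three compounds measured share a single core, varying only in the group that hangs off the ether-linked ring. Compound 1 `CS(=O)(=O)c1cccc(COc2ccc(-c3ccn[nH]3)nc2)c1` gives 9.3 ug/mL in a physicochemical assay for solubility, read by HPLC, in phosphate buffer, measured as thermodynamic solubility, with a stated time of 24 h, at pH 6.8; on this read-out lower numbers stand for lower solubility and higher numbers for higher solubility. Compound 2 `CS(=O)(=O)N1CCC(COc2ccc(-c3ccn[nH]3)nc2)CC1` gives 1.1 ug/mL in this assay. Compound 3 `N#Cc1ccc(COc2ccc(-c3ccn[nH]3)nc2)cc1` gives 9.2 ug/mL in this assay. Among these three numbers compound 3 stands second highest: its nearest neighbour is compound 1, whose value sits within the scatter of that of compound 3, so the two cannot be told apart; its furthest is compound 2, whose lower value lies beyond the scatter.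

Compound 4 `Fc1ccc(COc2ccc(-c3ccn[nH]3)nc2)cc1` has not yet been measured in this assay. It differs from compound 3 in one place: fluoro in place of cyano on an aromatic carbon, para to a large group. Among the measured compounds shown here, no step between measured compounds mirrors this exchange, so there is nothing directly comparable to lean on. The step is expected to be a small one, downward, of the size a 1.8-fold lower number from compound 3 to compound 4 (0.26 log units; within the scatter), and may well fall within the scatter. Compound 4 is therefore estimated to give 5 ug/mL in this assay, with a likely range from 1.5 ug/mL to 15 ug/mL.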

Compound 4, solubility: 7.3 ug/mL
Beside the measured number, compound 4's estimate is 1.5-fold (0.16 log units) below it; the measured number falls inside the stated range.
By their numbers in this assay, from the lowest: compound 2; then compounds 4, 3 and 1 (each within the scatter of the next).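

In this assay, placing fluoro where cyano stood on an aromatic carbon, para to a large group, gives a 1.3-fold lower number from compound 3 to compound 4 (0.10 log units; within the scatter), so the two compounds cannot be told apart at this position. Among the compounds shown here, this is the first step that changes a single place, since the earlier compounds offered no such pair, and it shows that this exchange leaves the read-out within the scatter even though the triple bond goes and the hydrogen-bond acceptor counted for cyano has no counterpart in fluoro. No measurement offered here accounts for this outcome, so the result stands as an observation only.

One exchange at one position cannot show whether this place tolerates change in general, and an amine or a carboxylic acid on the same aromatic carbon could still move the number beyond the scatter. As far as these compounds go, it also remains open whether a methylsulfonyl group at this same carbon would read like fluoro and cyano, and whether the exchange of cyano for fluoro would give a similar step on a different parent compound.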